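The source may report more compounds than this note shows. Statements on the series, on what has been measured and on what is new or still open speak of the compounds shown alone.

Compounds measured so far in a functional assay on MGC-803 cells (Homo sapiens) for antiproliferative activity, read by MTT assay, with a stated time of 72 h; a lower number here means a stronger inhibitor, a higher number a weaker inhibitor:

Compound 1 `CCCSc1nc(N/N=C(\C)c2ccc(O)cc2)c2nnn(Cc3ccccc3)c2n1`: 16700 nM
Compound 2 `CCCSc1nc(N/N=C/c2ccc(Cl)cc2)c2nnn(Cc3ccccc3)c2n1`: a limit of the assay, > 64000 nM
Compound 3 `CCCSc1nc(N/N=C/c2cccs2)c2nnn(Cc3ccccc3)c2n1`: a limit of the assay, > 64000 nM

Compound 3 stands at a limit, not at a number, in this assay. Compound 2 likewise stands only at a limit, so the step that the two limits leave unreadable from compound 2 to compound 3 cannot be read. Compound 1 is the only one of the three with a measured value, and both steps away from it run the same way: an at least 3.8-fold higher number from compound 1 to compound 2 (0.58 log units; beyond the scatter) and an at least 3.8-fold higher number from compound 1 to compound 3 (0.58 log units; beyond the scatter). Two of the three values sit at the same place, (the limit of > 64000 nM in this assay, at which 2 of the 3 values shown sit).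

Compound 4 `CCCSc1nc(N/N=C(\C)c2ccccc2O)c2nnn(Cc3ccccc3)c2n1` differs from compound 3 in one place: a group of 10 heavy atoms (8 carbon, 1 nitrogen, 1 oxygen; one six-membered aromatic ring of carbon only) in place of a group of 7 heavy atoms (5 carbon, 1 nitrogen, 1 sulfur; one five-membered aromatic ring with 1 hetero atom), on a nitrogen on an aromatic ring. The group that enters is, by its counts, the same kind of group that compound 1 carries and that compound 3 lacks, and the step of an at least 3.8-fold higher number from compound 1 to compound 3 (0.58 log units; beyond the scatter) went the other way when that group was removed. He therefore expects compound 4 to return to a number rather than a limit, with an estimated 20000 nM (range 7000 nM to 60000 nM), which would mean an expected step of an at least 3.2-fold lower number from compound 3 to compound 4 (0.50 log units; beyond the scatter) in this assay.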

Compound 4, half-maximal inhibitory concentration: 2310 nM
Estimate against measurement, compound 4: 8.7-fold (0.94 log units) above; the whole stated range lies above it.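

In this assay, for the compounds shown here, moving the hydroxyl alone changes the result: 2-hydroxyphenyl in place of 4-hydroxyphenyl on a carbon with a double bond to nitrogen gives a 7.2-fold lower number from compound 1 to compound 4 (0.86 log units; beyond the scatter), a comparison of two measured numbers that the earlier compounds could not offer. The group on this nitrogen also spans a wider range than compound 1 alone revealed, with an at least 27-fold lower number from compound 3 to compound 4 (1.44 log units; beyond the scatter) and an at least 27-fold lower number from compound 2 to compound 4 (1.44 log units; beyond the scatter). Those two steps are minimum sizes only, because compound 2 and compound 3 each stand at a limit of the assay and not at a number: the limit of > 64000 nM in this assay, at which 2 of the 4 values shown sit.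

The group in compound 4 differs from that of compound 3 in several features at once, among them one hydrogen-bond donor against none, and the compounds shown do not tell which feature carries the step. As far as these compounds go, it also remains open whether a methoxy group or an amine in place of the hydroxyl of compound 4 would keep its value in this assay.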